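The compounds below may be only part of what the source reports. "The series", "measured", "known", "first", "only" and "open" are said of these compounds alone.

Measured so far:
compound 1 `COc1ccc(/C=C/C(=O)c2c(C)[n+]([O-])c3ccccc3[n+]2[O-])cc1` — 11000 nM
compound 2 `Cc1c(C(=O)/C=C/c2ccc(Cl)c(Cl)c2)[n+]([O-])c2ccccc2[n+]1[O-]` — 15000 nM

Going by the values given here, in a functional assay on HSC-4 cells (Homo sapiens) for cytotoxicity, with a stated time of 48 h (a higher number here means that more compound is tolerated, a lower number that less compound is tolerated), compound 2 gives 15000 nM, one of only two numbers known; its nearest neighbour is compound 1, and the step of a 1.4-fold higher number from compound 1 to compound 2 (0.13 log units; within the scatter) is within the scatter, so the two compounds cannot be told apart. Compound 3 `Cc1ccc(/C=C/C(=O)c2c(C)[n+]([O-])c3ccccc3[n+]2[O-])cc1` is not yet measured. Its change from compound 2 is 4-methylphenyl in place of 3,4-dichlorophenyl on a double-bonded chain carbon bound to a double-bonded chain carbon. Among the compounds with values here, the only measured step that bears on this is the one swapping an aryl group on the same chain carbon, a 1.4-fold higher number from compound 1 to compound 2 (0.13 log units; within the scatter), which stayed within the scatter. On that basis the step of a 1.3-fold lower number from compound 2 to compound 3 (0.10 log units; within the scatter) is expected to be none beyond the scatter, in no fixed direction. Compound 3 is therefore estimated to give about 12000 nM in this assay, with a plausible range from 5000 nM to 30000 nM.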

Compound 3, half-maximal cytotoxic concentration: 11000 nM
Beside the measured number, compound 3's estimate is 1.1-fold (0.04 log units) above it, and the stated range covers the measured number.
By their numbers in this assay, from the lowest: compounds 1, 3 and 2 (each within the scatter of the next).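

In this assay, a second swap of the aryl group on a double-bonded chain carbon bound to a double-bonded chain carbon gives a 1.4-fold lower number from compound 2 to compound 3 (0.13 log units; within the scatter), so this position has now stayed within the scatter for another pair of groups. The new compound also allows a narrower comparison, methyl in place of methoxy on an aromatic carbon, and this gives no change at the digits printed from compound 1 to compound 3 (within the scatter), leaving 4-methoxyphenyl, 4-methylphenyl and 3,4-dichlorophenyl impossible to tell apart in these three compounds. Nothing available here accounts for this result.

Still open, from the compounds shown here alone, is whether a different kind of group at this position, such as an amine or a carboxylic acid on the aromatic ring, or a longer chain in place of the ring, would move the number beyond the scatter. Going by these compounds, the core is the same in all three compounds, and what a change there would do also remains open.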